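Working notes: from compound 3 to compound 4

The source may report more compounds than this note shows. Statements on the series, on what has been measured and on what is new or still open speak of the compounds shown alone.

Measured so far in an assay on LM cells for displacement of a labelled ligand from Neuropeptide Y receptor type 5 (Homo sapiens); a lower number here means a stronger inhibitor, a higher number a weaker inhibitor:
compound 1 `Fc1ccc(C2(c3ccc(F)cc3)CNC(c3ccccc3)=N2)cc1`: 32 nM
compound 2 `CC(=O)c1cccc(C2=NC(c3ccc(F)cc3)(c3ccc(F)cc3)CN2)c1`: 44 nM
compound 3 `Nc1cccc(C2=NC(c3ccc(F)cc3)(c3ccc(F)cc3)CN2)c1`: 300 nM

Compound 3 stands highest of the three numbers: a 6.8-fold higher number from compound 2 to compound 3 (0.83 log units; beyond the scatter) and a 9.4-fold higher number from compound 1 to compound 3 (0.97 log units; beyond the scatter), both beyond the scatter. Compound 4 `Fc1ccc(C2(c3ccc(F)cc3)CNC(c3ccsc3)=N2)cc1` carries thiophen-3-yl in place of 3-aminophenyl on a carbon with a double bond to nitrogen. For the measured compounds named here, no measured step exchanges one aromatic ring for another of a different kind; the only steps that bear on the change are those that bring the amino group in, a 9.4-fold higher number from compound 1 to compound 3 (0.97 log units; beyond the scatter) and a 6.8-fold higher number from compound 2 to compound 3 (0.83 log units; beyond the scatter), both modest rises. Compound 4 removes that amino group together with the six-membered ring of carbon only, so a fall of roughly that size is expected, back toward the numbers of compound 1 and compound 2, while the exchange for a five-membered ring with one hetero atom is not covered by any step and widens the range. For compound 4 the expected step is a 6.0-fold lower number from compound 3 to compound 4 (0.78 log units; beyond the scatter). Compound 4 is accordingly estimated at 50 nM, with a range from 15 nM to 160 nM.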

Compound 4, half-maximal inhibitory concentration: 93 nM
Estimate against measurement, compound 4: 1.9-fold (0.27 log units) below, and the stated range covers the measured number.
By their numbers in this assay, from the lowest: compounds 1 and 2 (each within the scatter of the next); then compound 4; then compound 3.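

In this assay, the carbon with a double bond to nitrogen accepts a five-membered aromatic ring with 1 hetero atom, at a modest cost against the unsubstituted phenyl: a 2.9-fold higher number from compound 1 to compound 4 (0.46 log units; beyond the scatter). Thiophen-3-yl recovers only part of what the 3-aminophenyl group gives up, with a 3.2-fold lower number from compound 3 to compound 4 (0.51 log units; beyond the scatter), so the removal of the amino-bearing ring does not return the number to that of compound 1. Against the 3-acetylphenyl group the exchange also gives a modest rise, a 2.1-fold higher number from compound 2 to compound 4 (0.33 log units; beyond the scatter), which places compound 4 between compounds 1 and 2 on one side and compound 3 on the other.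

Nothing available explains these steps. The compounds shown do not separate ring size from the sulfur atom, and furan-3-yl or pyridin-3-yl on this carbon would bear on that question, as would an acetyl or amino group on the thiophene ring.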